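A few compounds are considered here, and "the series" means these few. Any claim that something is new, unique, unknown or untested is made for them only; others in the source may bear on it.

Compound 1 `Clc1cnc(Nc2cn[nH]c2)nc1Nc1ccccc1`: 5380 nM
Compound 2 `Fc1ccc(Nc2nc(Nc3cn[nH]c3)ncc2Cl)cc1`: 1030 nM

Both values come from a functional assay on PC-3 cells (Homo sapiens) for antiproliferative activity, read by MTT assay, with a stated time of 48 h; a higher number here means a weaker inhibitor, a lower number a stronger inhibitor. Of the two, compound 2 has the lower number, 1030 nM, which makes it the stronger inhibitor of the pair. Compound 3 `Clc1ccccc1Nc1nc(Nc2cn[nH]c2)ncc1Cl` has not yet been measured. It differs from compound 2 as follows: 2-chlorophenyl in place of 4-fluorophenyl on a nitrogen on an aromatic ring. In words, 2-chlorophenyl stands in place of 4-fluorophenyl on a nitrogen on an aromatic ring. Among the measured compounds shown here, only one measured step bears on this change: a 5.2-fold lower number from compound 1 to compound 2 (0.72 log units; beyond the scatter), a modest gain on adding fluoro. For the measured compounds named here, no measured compound carries 2-chlorophenyl, so the direction is uncertain. Since compound 3 lacks the fluoro behind a 5.2-fold lower number from compound 1 to compound 2 (0.72 log units; beyond the scatter), a modest rise in this assay is expected, though not a full return to the number of compound 1. The expected step is a 2.4-fold higher number from compound 2 to compound 3 (0.39 log units; beyond the scatter). Compound 3 is estimated at 2500 nM, with an expected range of 800 nM to 7500 nM.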

Compound 3, half-maximal inhibitory concentration: 1130 nM
Compound 3: middle estimate off by 2.2-fold (0.34 log units), on the high side; low and high end bracket the measured number.
By their numbers in this assay, from the lowest: compounds 2 and 3 (each within the scatter of the next); then compound 1.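

In this assay, 2-chlorophenyl in place of 4-fluorophenyl on the nitrogen gives a 1.1-fold higher number from compound 2 to compound 3 (0.04 log units; within the scatter), so the two groups cannot be told apart here. Adding a chloro to the phenyl gives a 4.8-fold lower number from compound 1 to compound 3 (0.68 log units; beyond the scatter), showing that the earlier gain over the unsubstituted phenyl of compound 1 is not confined to fluoro: among these three compounds, both halogen-bearing phenyl groups share it, and none goes against this. Nothing measured on these groups is at hand to account for this.

The compounds shown leave open whether the halogen itself matters or only its presence on the phenyl, since 2-chlorophenyl and 4-fluorophenyl differ in both the halogen and its printed ring number. They also leave open how a phenyl carrying an amine, a methoxy group or a carboxylic acid would behave on this nitrogen.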